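Swapping the Fluoroanilino Group for a Piperidine Ring

The source may hold more compounds than are shown below. What is called first, only, known or untested is meant among the compounds shown, and "the series" means these compounds.

In a functional assay on ECa-109 cells for inhibition, with ECa-109 cell line (Homo sapiens) as the target, read by sulforhodamine B assay (on this read-out lower numbers stand for stronger inhibition and higher numbers for weaker inhibition), compound 1 `O=C1C(Nc2ccccc2F)=CC(=O)c2c1nc1n2[C@H]2OC[C@@H](O)[C@H]2OC1` gives 2660 nM, the lowest of the two numbers shown. Compound 3 `O=C1C=C(Nc2cccc(F)c2)C(=O)c2c1nc1n2[C@H]2OC[C@@H](O)[C@H]2OC1` gives 7030 nM in this assay, a higher number. Compound 2 `O=C1C=C(NC2CCCCC2)C(=O)c2c1nc1n2[C@H]2OC[C@@H](O)[C@H]2OC1` is reported in this assay only as a limit, > 16000 nM. Among the compounds with values here, the one measured step, an at least 2.2-fold lower number from compound 2 to compound 3 (0.35 log units; beyond the scatter), runs from a saturated ring to an aromatic ring on the amine nitrogen and lowers the number. Compound 4 `O=C1C(N2CCCCC2)=CC(=O)c2c1nc1n2[C@H]2OC[C@@H](O)[C@H]2OC1` differs from compound 1 by piperidin-1-yl in place of (2-fluorophenyl)amino on a double-bonded ring carbon, a move back toward a saturated ring while also losing the hydrogen-bond donor. Compound 4 is therefore expected to show a higher number, around a 6.0-fold higher number from compound 1 to compound 4 (0.78 log units; beyond the scatter). Compound 4 is estimated at 16000 nM, between 5000 nM and 50000 nM, with a real chance that only a limit is reported.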

Compound 4, half-maximal inhibitory concentration: > 8000 nM
Compound 4 gave a limit, no number; the forecaster's own chance of this, stated with the estimate: 55%; the middle value lies beyond the limit too.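

In this assay, piperidin-1-yl on this double-bonded ring carbon gives an at least 3.0-fold higher number from compound 1 to compound 4 (0.47 log units; beyond the scatter), the first step shown that starts from compound 1. As far as these compounds go, the full size of this step stays unknown because compound 4 is reported only as a limit: the limit of > 8000 nM in this assay, at which 1 of the 4 values shown sits. At this place, (2-fluorophenyl)amino thus gives the lower number, though the change removes the aromatic ring and the hydrogen-bond donor together.

The compounds shown do not separate these two losses. A methyl(phenyl)amino group, which keeps the aromatic ring without the amine hydrogen, would bear on that question.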